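Swapping chlorines for fluorines on the aryl ketone of compound 1

The compounds below may be only part of what the source reports. "The series", "measured", "known", "first", "only" and "open" are said of these compounds alone.

Measured compounds:
compound 1, `COc1cc(-c2cc(/C=C/C(=O)c3ccc(Cl)c(Cl)c3)[nH]n2)cc(OC)c1OC`, 54%
compound 2, `COc1ccc(-c2cc(/C=C/C(=O)c3ccc(N)cc3)[nH]n2)cc1`, 100%
compound 3, `COc1cc(C(=O)/C=C/c2cc(-c3cc(OC)c(OC)c(OC)c3)n[nH]2)cc(OC)c1OC`, 98%

Of the compounds shown here, three have been tested in a functional assay on COLO 205 cells (Homo sapiens) for cytotoxicity, read by sulforhodamine B assay, with a stated time of 48 h, tested at 1 uM; a lower number here means a stronger effect, a higher number a weaker effect of the compound at the concentration tested. Compound 1 stands lowest of the three, so it shows the strongest effect: compound 3 lies higher by a gap beyond the scatter, and compound 2 lies higher still, also beyond the scatter. Compound 2 gives 100%, which is as weak as the read-out can be.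

The next compound, compound 4, `COc1cc(-c2cc(/C=C/C(=O)c3ccc(F)c(F)c3)[nH]n2)cc(OC)c1OC`, keeps the shared core of compound 1 and changes only the ring on the carbonyl carbon: 3,4-difluorophenyl in place of 3,4-dichlorophenyl on a carbonyl carbon

Going by the values given here, no step between two measured compounds isolates such a halogen swap, so the size of this step cannot be read from the data. Since chlorine and fluorine sit at the same two places on the same ring, the change is expected to be modest, most likely towards a weaker effect, though it may stay within the scatter. The step from compound 1 to compound 4 is estimated as a number 18 percentage points higher from compound 1 to compound 4 (beyond the scatter). Compound 4 is expected to give about 72%, within a range from 50% to 98%.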

Compound 4, a percentage reported as activity, at one concentration (the size of the read-out at that concentration, not a potency): 92%
Estimate against measurement, compound 4: 20 percentage points below; the measured number falls inside the stated range.
By their numbers in this assay, from the lowest: compound 1; then compounds 4, 3 and 2 (each within the scatter of the next).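

In this assay, the ring on the carbonyl carbon proves sensitive to which halogen it carries: 3,4-difluorophenyl in place of 3,4-dichlorophenyl gives a number 38 percentage points higher from compound 1 to compound 4 (beyond the scatter) and so costs compound 1 much of its effect. Going by these compounds alone, this is the first step that changes one place only, and the two groups match in heavy-atom count, in ring and in their lack of hydrogen-bond donors and acceptors, differing only in the halogen. Nothing measured here explains why the two halogens behave so differently.

Still open, on these data alone, is whether both chlorines are needed, which a ring with a single chlorine would test. Bromine atoms or methyl groups at the same two places would show whether the effect of compound 1 is specific to chlorine.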